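The source may report more compounds than this note shows. Statements on the series, on what has been measured and on what is new or still open speak of the compounds shown alone.

Compound 3 `O=C(NCCCCCCc1ccccc1)N1CCN(c2cccc(-n3cccc3)c2)CC1` stands second highest of the three numbers in an assay on brain for inhibition of Fatty-acid amide hydrolase 1 (Mus musculus), with stated times of 20 min and 15 min (a higher number here means a weaker inhibitor, a lower number a stronger inhibitor), where compound 3 gives 263 nM; compound 1 `N#Cc1ccn(-c2cccc(N3CCN(CCCCCCc4ccccc4)CC3)c2)c1` gives 270 nM, and compound 2 `NC(=O)c1ccn(-c2cccc(N3CCN(CCCCCCc4ccccc4)CC3)c2)c1` gives 10 nM. Compound 4 `NC(=O)c1ccn(-c2cccc(N3CCN(C(=O)NCCCCCCc4ccccc4)CC3)c2)c1` differs from compound 3 by carbamoyl in place of hydrogen on an aromatic carbon. Among the measured compounds shown here, the only measured step that bears on it is the change from cyano to carbamoyl at the same carbon, which gave a 27-fold lower number from compound 1 to compound 2 (1.43 log units; beyond the scatter). Since the entering group here is the same carbamoyl, a large step toward a lower number is expected, estimated as an 18-fold lower number from compound 3 to compound 4 (1.24 log units; beyond the scatter). Compound 4 is therefore expected to give about 15 nM in this assay, within a range from 4 nM to 60 nM.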

Compound 4, inhibition constant: > 500 nM
Compound 4 was reported as a limit (the forecaster's own chance of this, stated with the estimate: 2%); middle value at least 33-fold (1.52 log units) from the limit.
By their numbers in this assay, from the lowest: compound 2; then compounds 3 and 1 (each within the scatter of the next). At a limit, above all of these: compound 4.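

Carbamoyl in place of hydrogen on this aromatic carbon, two ring bonds from the ring nitrogen, gave an at least 1.9-fold higher number from compound 3 to compound 4 (0.27 log units; that floor lies within the scatter) in this assay, so no gain appears. Compound 4 gives > 500 nM, which is a limit of the assay and not a number. The earlier step, a 27-fold lower number from compound 1 to compound 2 (1.43 log units; beyond the scatter), replaced cyano on a compound without the chain carbonyl of compound 4, and its large drop does not carry over to this compound.

From the compounds shown here alone, how far compound 4 lies past its limit stays open. Also open, going by these compounds, is how an amine or a carboxylic acid at this carbon would behave with either chain.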